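The compounds below may be only part of what the source reports. "The series", "measured", "known", "first", "only" and "open" are said of these compounds alone.

Working notes on the series. In a functional assay on the whole organism with Mus musculus as the target (a lower number here means that less compound is needed, a higher number that more compound is needed for the effect), compound 1 (`CN(C)C(=O)Cn1c(-c2ccc(Br)cc2)nc2cccnc21`) gives 7 mg/kg and compound 2 (`CN(C)C(=O)Cn1c(-c2ccc([N+](=O)[O-])cc2)nc2cccnc21`) gives 47 mg/kg. Compound 2 therefore holds the higher of the two numbers, so more of it is needed for the effect. Compound 3 (`Cc1ccc(-c2nc3cccnc3n2CC(=O)N(C)C)cc1`) keeps the rest of compound 2 and carries methyl in place of nitro on an aromatic carbon, para to a large group: methyl in place of nitro on an aromatic carbon.

Among the measured compounds shown here, one measured step bears on this change, nitro in place of bromo: a 6.7-fold higher number from compound 1 to compound 2 (0.83 log units; beyond the scatter). That step is modest but beyond the scatter. For the measured compounds named here, of the two groups measured at this place, nitro goes with the higher number, but no measured compound carries methyl, and methyl has not been compared with bromo. A move back toward compound 1 in this assay is therefore expected, though not necessarily all the way. The estimated change is a 3.9-fold lower number from compound 2 to compound 3 (0.59 log units; beyond the scatter), a step downward somewhat smaller than the measured one. For compound 3 the expected value is 12 mg/kg, with an estimated range of 4 mg/kg to 35 mg/kg.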

Compound 3, dose for half-maximal effect: 4.7 mg/kg
Estimate against measurement, compound 3: 2.6-fold (0.41 log units) above, and the stated range covers the measured number.
By their numbers in this assay, from the lowest: compounds 3 and 1 (each within the scatter of the next); then compound 2.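

Replacing nitro with methyl on the aromatic carbon in this assay gives a 10-fold lower number from compound 2 to compound 3 (1.00 log units; beyond the scatter) and shows that the higher number of compound 2 now stands against two other groups at this place, not just bromo. Methyl and bromo are not separated here: the comparison gives a 1.5-fold lower number from compound 1 to compound 3 (0.17 log units; within the scatter) and so compound 2 alone stands apart among the three, with methyl serving as well as bromo at this place. No measurement on hand accounts for why nitro differs from the other two groups.

The compounds shown leave open whether an amine, a carboxylic acid or a methoxy group at this place would stay with methyl and bromo or move toward nitro. They also leave open whether the same order of groups would hold if the amide side chain on the shared core were replaced by a longer chain.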